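Dibenzylidene cyclohexanone series: methoxy count on the aryl ring

The source may report more compounds than this note shows. Statements on the series, on what has been measured and on what is new or still open speak of the compounds shown alone.

Compound 1 `COc1ccc(/C=C2\CCC/C(=C\c3cccc(OC)c3OC)C2=O)cc1` gives 18600 nM in a functional assay on MCF7 cells (Homo sapiens) for cytotoxicity, read by MTT assay, with a stated time of 72 h; on this read-out higher numbers stand for weaker inhibition and lower numbers for stronger inhibition. Compound 2 `COc1ccc(/C=C2\CCC/C(=C\c3cccc(OC)c3OC)C2=O)cc1OC` carries one more methoxy group, and in this assay compound 2 gives 6500 nM, a step of a 2.9-fold lower number from compound 1 to compound 2 (0.46 log units; beyond the scatter) for the change (methoxy in place of hydrogen on an aromatic carbon). Compound 3 `COc1cc(/C=C2\CCC/C(=C\c3ccc(OC)c(OC)c3)C2=O)cc(OC)c1` gives 3900 nM in this assay; the difference between the core of compound 3 and the core of compound 1 is not broken down here. Compound 4 `COc1ccc(/C=C2\CCC/C(=C\c3cc(OC)c(OC)c(OC)c3)C2=O)cc1OC` is not yet measured and differs from compound 3 by methoxy in place of hydrogen on an aromatic carbon. Among the measured compounds shown here, this is the same kind of change as the one from compound 1 to compound 2, but the surroundings are not identical: in compound 2 the entering methoxy sits ortho to a methoxy group and meta to a large group, while in compound 4 it sits ortho to two methoxy groups and para to a large group. For the measured compounds named here, the earlier step stands as the only guide. For compound 4 the expected step is a 2.0-fold lower number from compound 3 to compound 4 (0.29 log units; within the scatter), somewhat smaller than the earlier one, because the step of a 2.9-fold lower number from compound 1 to compound 2 (0.46 log units; beyond the scatter) was modest and the surroundings differ. Compound 4 is therefore estimated at 2000 nM, with a range from 800 nM to 5000 nM.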

Compound 4, half-maximal inhibitory concentration: 1600 nM
Estimate against measurement, compound 4: 1.3-fold (0.10 log units) above; the measured number falls inside the stated range.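

In this assay, methoxy in place of hydrogen on an aromatic carbon gives a 2.4-fold lower number from compound 3 to compound 4 (0.39 log units; beyond the scatter) and thus moves the number in the same direction as on the core of compound 1. Set side by side, the two steps agree in direction and do not differ in size: the same change on two cores in this assay, a 2.9-fold lower number (0.46 log units; beyond the scatter) from compound 1 to compound 2 and a 2.4-fold lower number (0.39 log units; beyond the scatter) from compound 3 to compound 4, 1.2-fold (0.07 log units) apart, within the scatter of two such steps. This supports carrying the change between these two cores, even with the entering methoxy ortho to two methoxy groups and para to a large group in compound 4, but it rests on one pair per core and does not show that the step would hold on any other core or at any other place on the ring.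

All the aryl substituents shown are methoxy groups, so it remains open whether a hydroxy group, a fluorine atom or an amine at the same place would give a comparable step. From the compounds shown here alone, a longer chain such as ethoxy in place of methoxy is equally open, as is the behaviour of this change outside this assay.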